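Swapping furan-2-yl for pyridin-4-yl in compound 2

This account rests on a few compounds, and the source may have more. Where it says the series, first, only, none or still open, it means among the compounds named here.

In a functional assay on Jurkat cells (Homo sapiens) for inhibition, read by CCK-8 assay, with a stated time of 48 h (a lower number here means a stronger inhibitor of growth, a higher number a weaker inhibitor of growth), compound 1 (`Cc1ccccc1Nc1nc(Nc2cccnc2)ncc1Cl`) gives 38600 nM. Compound 2 (`Cc1ccccc1Nc1nc(NCc2ccco2)ncc1Cl`) gives > 100000 nM, which is a limit and not a number.

Compound 3 (`Cc1ccccc1Nc1nc(NCc2ccncc2)ncc1Cl`) has pyridin-4-yl in place of furan-2-yl on a saturated chain carbon bound to a nitrogen on an aromatic ring.

Going by the values given here, one measured step bears on this change: an at least 2.5-fold higher number from compound 1 to compound 2 (0.41 log units; beyond the scatter). It is at least modest, and it swapped pyridin-3-yl for (furan-2-yl)methyl, so it changed more than the ring. Compound 3 brings back a ring with a ring nitrogen, but keeps the chain, so only part of that step is expected to return. The estimated change is an at least 1.5-fold lower number from compound 2 to compound 3 (0.18 log units; that floor lies within the scatter), a modest move towards a lower number in this assay. For compound 3 the expected value is 65000 nM, with an estimated range of 25000 nM to 100000 nM.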

Compound 3, concentration for 50% growth inhibition: > 100000 nM
Compound 3 was reported as a limit; the forecaster's own chance of this, stated with the estimate: 45%; middle value at least 1.5-fold (0.18 log units) from the limit.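

Compound 3, like compound 2, is reported only as a limit in this assay, so the step between them cannot be read. The step that can be read is an at least 2.5-fold higher number from compound 1 to compound 3 (0.41 log units; beyond the scatter), which shows that a pyridine ring carried on a saturated chain carbon does not restore the growth inhibition of compound 1, even though it brings back the ring nitrogen that furan-2-yl lacks. Neither ring on this chain carbon gives a value that can be read, so any gain from pyridin-4-yl over furan-2-yl stays out of sight: the limit of > 100000 nM in this assay, at which 2 of the 3 values shown sit.

The compounds shown do not tell whether the added chain carbon or the change of ring matters more in the steps away from compound 1. A (pyridin-3-yl)methyl group or a longer chain at this place could help separate the two.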